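Adding a Methyl Group to Compound 2

The compounds below may be only part of what the source reports. "The series", "measured", "known", "first", "only" and "open" are said of these compounds alone.

Values in a functional assay on A549 cells (Homo sapiens) for antiproliferative activity, read by MTT assay, with a stated time of 72 h; a lower number here means a stronger inhibitor, a higher number a weaker inhibitor
- Compound 1 `O=C1C=C(N2CCN(c3ccccc3Cl)CC2)C(=O)c2c(O)cccc21` gives 4500 nM
- Compound 2 `O=C1C=C(N2CCC(c3ccccc3)CC2)C(=O)c2c(O)cccc21` gives > 50000 nM as a limit of the assay

Only compound 1 of this pair has a measured number. Compound 2 reads > 50000 nM, and this is a limit of the assay, not a number. Within the data shown here, no measured step links the two compounds, so nothing here shows directly how a change of this kind acts.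

Compound 3 `Cc1ccccc1C1CCN(C2=CC(=O)c3cccc(O)c3C2=O)CC1` comes from compound 2 through one structural change: methyl in place of hydrogen on an aromatic carbon. This is methyl in place of hydrogen on an aromatic carbon, ortho to a large group, which turns phenyl into 2-methylphenyl.

Among the measured compounds shown here, the only starting point is compound 2 with > 50000 nM, so compound 3 is expected to stay close to that limit. The estimated at least 1.2-fold lower number from compound 2 to compound 3 (0.09 log units; that floor lies within the scatter) is small, with no change beyond the scatter expected in this assay. The assay may again report only a limit. Compound 3 is expected to give 40000 nM, with an estimated range from 12000 nM to 80000 nM.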

Compound 3, half-maximal inhibitory concentration: 5200 nM
Compound 3: middle estimate off by 7.7-fold (0.89 log units), on the high side; the measured number lies below the stated range.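

On this ring, a single added carbon is enough to change the reading. In this assay, methyl in place of hydrogen on an aromatic carbon, ortho to a large group, gives an at least 9.6-fold lower number from compound 2 to compound 3 (0.98 log units; beyond the scatter), so the step from phenyl to 2-methylphenyl moves the series from an unquantified reading to a measured one, which neither earlier compound could show at this position. Compound 2 reads > 50000 nM, and this is a limit of the assay, not a number. The true size of the step therefore stays unknown, and only its lower bound can be stated, because one end of the pair is not a number: the limit of > 50000 nM in this assay, at which 1 of the 3 values shown sits.

The compounds shown leave open whether this gain belongs to methyl itself or would also appear with another group in the same place, such as ethyl, methoxy, chlorine or an amine. They also leave open whether methyl on a different carbon of this ring would give a step of similar size, since this single pair speaks for one place and one group only.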